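A few compounds are considered here, and "the series" means these few. Any claim that something is new, unique, unknown or untested is made for them only; others in the source may bear on it.

Measured in a functional assay on PC-3 cells (Homo sapiens) for inhibition, read by MTT assay, with stated times of 18 h and 4 h; on this read-out lower numbers stand for stronger inhibition and higher numbers for weaker inhibition:
- compound 1 `CCCOP(=O)(O)OCCSC(=S)N1CCCCC1`: > 100000 nM (a limit)
- compound 2 `CCCCCCOP(=O)(O)OCCSC(=S)N1CCCCCC1`: > 100000 nM (a limit)

Compound 2 gives > 100000 nM, which is a limit of the assay and not a number. No measured value for the series lies inside the range of the assay, as the summary shows: the limit of > 100000 nM in this assay, at which 2 of the 2 values shown sit. Among the measured compounds shown here, no single measured step is available, so the two compounds give no size or direction of change.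

The next compound is compound 3 `CCCCCCOP(=O)(O)OCCSC(=S)N1CCCCC1`, in which piperidin-1-yl stands in place of azepan-1-yl on a thiocarbonyl carbon: piperidin-1-yl in place of azepan-1-yl on a thiocarbonyl carbon. The rest of the structure is the same as in compound 2.

Since compound 2 reads > 100000 nM, the expectation in this assay is for no step beyond the usual scatter, and no direction is expected. The estimated step is a number no higher from compound 2 to compound 3 (the limit leaves the size open). A report of compound 3 as a limit of the assay is the likeliest outcome. For compound 3 the expected value is 100000 nM, with an estimated range of 50000 nM to 200000 nM.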

Compound 3, half-maximal inhibitory concentration: > 100000 nM
Compound 3 ended at the assay's limit; the forecaster's own chance of this, stated with the estimate: 85%; the middle value lies on the limit itself.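

In this assay compound 3 gives > 100000 nM, a limit and not a number. No step to compound 3 from compound 1 or compound 2 can be read, as all three compounds sit at the same limit: the limit of > 100000 nM in this assay, at which 3 of the 3 values shown sit.

The compounds shown leave open whether either change, in the ring or in the chain, alters inhibition at all.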